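Trading an Aryl Group for Hydrogen on a Ring Nitrogen

The compounds below may be only part of what the source reports. "The series", "measured", "known", "first", "only" and "open" are said of these compounds alone.

Of the compounds shown here, two sharing one core have been measured in a functional assay on SK-OV-3 cells (Homo sapiens) for antiproliferative activity, read by MTT assay, with a stated time of 72 h; a higher number here means a weaker inhibitor, a lower number a stronger inhibitor. Compound 1 `O=C1NC(=S)S/C1=C\N1N=C(c2ccc(Cl)cc2)CC1c1ccc(Cl)cc1` carries a hydrogen on the amide-type nitrogen of its five-membered ring, and a chlorophenyl group where compound 2 carries a naphthyl group; in this assay compound 1 gives 9140 nM. Compound 2 `CC(=O)Oc1cccc(N2C(=O)/C(=C/N3N=C(c4ccc5ccccc5c4)CC3c3ccc(Cl)cc3)SC2=S)c1` carries a 3-acetoxyphenyl group on that nitrogen; in this assay compound 2 gives 2390 nM, the lower of the two numbers, with the gap to compound 1 lying beyond the usual scatter. Since compound 1 and compound 2 differ in two places, their two values alone cannot say which change drives the gap.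

Compound 3 `O=C1NC(=S)S/C1=C\N1N=C(c2ccc3ccccc3c2)CC1c1ccc(Cl)cc1` keeps the naphthyl group of compound 2 and changes one thing: hydrogen in place of 3-acetoxyphenyl on an amide-type nitrogen in a ring. For the measured compounds named here, no pair of measured compounds differing in only one place exists here, so the effect of this change is uncertain. Compound 3 is expected to sit between the two measured values, a step toward a higher number of size a 2.1-fold higher number from compound 2 to compound 3 (0.32 log units; beyond the scatter). The estimate for compound 3 in this assay is 5000 nM, with a range from 1500 nM to 15000 nM.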

Compound 3, half-maximal inhibitory concentration: 163 nM
Beside the measured number, compound 3's estimate is 31-fold (1.49 log units) above it; the whole stated range lies above it.
By their numbers in this assay, from the lowest: compound 3; then compound 2; then compound 1.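

In this assay, hydrogen in place of 3-acetoxyphenyl on the amide-type nitrogen in the ring gives a 15-fold lower number from compound 2 to compound 3 (1.17 log units; beyond the scatter), so with the naphthyl group held fixed, the bare nitrogen reads far better than the aryl-bearing one. A second single change, naphthalen-2-yl in place of 4-chlorophenyl on a carbon with a double bond to nitrogen, gives a 56-fold lower number from compound 1 to compound 3 (1.75 log units; beyond the scatter), which shows that this other place also has a large effect when the amide-type nitrogen carries hydrogen. Together the two steps settle what compound 1 and compound 2 could not show alone: the two changes pull in opposite directions, and the modest gap between those compounds hides two large effects.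

Nothing measured here explains either step. Also open, on these data alone, is how a methyl group, a plain phenyl or a 3-hydroxyphenyl would read on that nitrogen, and whether 3-acetoxyphenyl would bring a step of similar size with 4-chlorophenyl in place of naphthalen-2-yl.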